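Replacing Trifluoromethyl with 3-Methylbut-2-en-1-yl on the Ether

A few compounds are considered here, and "the series" means these few. Any claim that something is new, unique, unknown or untested is made for them only; others in the source may bear on it.

Compound 1 `O=C(NNc1nncc2ccccc12)C1CC1c1ccc(OCC(F)(F)F)cc1` gives 8000 nM in a functional assay on MCF7 cells (Homo sapiens) for inhibition, read by MTT assay, with a stated time of 72 h; a lower number here means a stronger inhibitor, a higher number a weaker inhibitor. Compound 2 `O=C(NNc1nncc2ccccc12)C1CC1c1ccc(OC(F)(F)F)cc1` gives 54000 nM. Compound 3 `O=C(NNC(=O)C1CC1c1ccc(OCC(F)(F)F)cc1)c1ccncc1` gives 34000 nM.

Compound 2 has the highest number of the three: compound 3 stands within the scatter of it, while compound 1 lies clearly below. Compound 4 `CC(C)=CCOc1ccc(C2CC2C(=O)NNc2nncc3ccccc23)cc1` differs from compound 2 by 3-methylbut-2-en-1-yl in place of trifluoromethyl on an oxygen on an aromatic ring. Within the data shown here, the one measured step touching this position is a 6.8-fold higher number from compound 1 to compound 2 (0.83 log units; beyond the scatter), a change at the same oxygen. Among the measured compounds shown here, no measured compound carries the entering group, so the expectation rests on that single step: moving from trifluoromethyl back to a longer chain on the oxygen is expected to give a modest drop in this assay, a 4.5-fold lower number from compound 2 to compound 4 (0.65 log units; beyond the scatter). Compound 4 is therefore estimated at 12000 nM, with a range from 3000 nM to 50000 nM.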

Compound 4, half-maximal inhibitory concentration: 69000 nM
The estimate for compound 4 lay 5.8-fold (0.76 log units) below the measured number, outside the stated range (above it).
By their numbers in this assay, from the lowest: compound 1; then compounds 3, 2 and 4 (each within the scatter of the next, the first and the last beyond it).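

In this assay a longer chain on the oxygen does not by itself bring the lower number: 3-methylbut-2-en-1-yl and trifluoromethyl read alike (a 1.3-fold higher number from compound 2 to compound 4 (0.11 log units; within the scatter)). Among the three ethers on the shared core, 2,2,2-trifluoroethyl alone stands apart (an 8.6-fold higher number from compound 1 to compound 4 (0.94 log units; beyond the scatter)), so the earlier step from compound 1 to compound 2 does not reflect chain length alone. Nothing measured here offers a reason for this.

As far as these compounds go, it remains open whether a plain ethyl chain on the oxygen would read like compound 1 or like compounds 2 and 4. A saturated 3-methylbutyl chain would likewise test whether the double bond matters.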